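Compound 1 to compound 4: a step at the limit

A few compounds are considered here, and "the series" means these few. Any claim that something is new, unique, unknown or untested is made for them only; others in the source may bear on it.

compound 1 `Cc1ccc(Nc2ncc(C(F)(F)F)c(N3Cc4cccc(N(C)S(C)(=O)=O)c4C3)n2)cc1C`: > 30000 nM
compound 2 `COc1cc(N2CCN(C(C)=O)CC2)ccc1Nc1ncc(C(F)(F)F)c(N2Cc3cccc(N(C)S(C)(=O)=O)c3C2)n1`: 3300 nM
compound 3 `Cc1cc(F)ccc1Nc1ncc(C(F)(F)F)c(N2Cc3cccc(N(C)S(C)(=O)=O)c3C2)n1`: > 30000 nM

In a functional assay on A549 cells (Homo sapiens) for antiproliferative activity, read by spectrophotometry, with a stated time of 2 days (on this read-out lower numbers stand for stronger inhibition of growth and higher numbers for weaker inhibition of growth), compound 1 gives > 30000 nM as a limit of the assay and not a number. Compound 3 gives > 30000 nM as a limit too. Compound 2 gives a true number, 3300 nM in the same read-out. The set therefore shows the limit of > 30000 nM in this assay, at which 2 of the 3 values shown sit, and has little numeric footing.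

Compound 4 `CN(c1cccc2c1CN(c1nc(Nc3ccc(C(F)(F)F)cc3)ncc1C(F)(F)F)C2)S(C)(=O)=O` carries this change from compound 1: 4-(trifluoromethyl)phenyl in place of 3,4-dimethylphenyl on a nitrogen on an aromatic ring and the rest of the structure stays the same.

For the measured compounds named here, the only measured step at this nitrogen is a step that the two limits leave unreadable from compound 1 to compound 3 with 4-fluoro-2-methylphenyl in place of 3,4-dimethylphenyl, and it gives no size to carry over. The expectation rests on that step, which stays at the limit at both ends. No readable gain in growth inhibition is expected, and the estimated change is a number no higher from compound 1 to compound 4 (the limit leaves the size open) with no clear direction. Compound 4 is expected at 30000 nM within an estimated range of 10000 nM to 60000 nM in this assay and will most likely be reported as a limit again.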

Compound 4, concentration for 50% growth inhibition: > 30000 nM
Compound 4: only a limit was reported; the forecaster's own chance of this, stated with the estimate: 75%; the middle value lies on the limit itself.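

In this assay compound 4 gives > 30000 nM, a limit of the assay and not a number. Its steps from compound 1 and from compound 3 therefore cannot be read. How 3,4-dimethylphenyl, 4-fluoro-2-methylphenyl and 4-(trifluoromethyl)phenyl rank on this nitrogen stays open, with the values stopping at one boundary: the limit of > 30000 nM in this assay, at which 3 of the 4 values shown sit.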